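Shortening the Acid Chain with a Sulfonyl Link

The source may report more compounds than this note shows. Statements on the series, on what has been measured and on what is new or still open speak of the compounds shown alone.

Among the measured compounds shown here, compound 1 `O=C(O)CCCCCCCCCn1nc(-c2ccccc2)c(-c2ccccc2)c1-c1ccccc1` is the only compound here with a full number in a functional assay for inhibition, with Homo sapiens as the target (a lower number here means a stronger inhibitor, a higher number a weaker inhibitor), where compound 1 gives 5500 nM. Compound 2 `O=C(O)CCCCCCCCCn1cc(-c2ccccc2)c(-c2ccccc2)n1` reaches only a limit of the assay in this assay, reported as > 81000 nM. The step of an at least 14-fold higher number from compound 1 to compound 2 (1.16 log units; beyond the scatter) shows how much the loss of one phenyl weakens inhibition. Compound 3 `O=C(O)CS(=O)(=O)CCCCCCn1nc(-c2ccccc2)c(-c2ccccc2)c1-c1ccccc1` keeps all three phenyl groups and alters the acid chain instead: (carboxymethyl)sulfonyl in place of 3-carboxypropyl on a saturated chain carbon, six bonds along the chain from an aromatic nitrogen. For the measured compounds named here, no measured step touches this chain, so the phenyl step offers no guide, and no change beyond the scatter is expected: a 1.5-fold higher number from compound 1 to compound 3 (0.16 log units; within the scatter). Compound 3 is therefore expected to give about 8000 nM, in a range from 2500 nM to 30000 nM.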

Compound 3, half-maximal inhibitory concentration: 22000 nM
For compound 3 the middle estimate is 2.8-fold (0.44 log units) below the measured one, and the stated range covers the measured number.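

The acid chain is not a neutral place to alter: in this assay, (carboxymethyl)sulfonyl in place of 3-carboxypropyl gives a 4.0-fold higher number from compound 1 to compound 3 (0.60 log units; beyond the scatter), even though all three phenyl groups stay. So inhibition responds to the chain as well as to the phenyl groups, with a modest step at this position. Nothing measured here accounts for this loss.

Going by these compounds, the sulfonyl and the carboxymethyl end enter together, and their separate shares remain open. On these data alone, how a sulfide or an amide at this place on the chain would compare also stays open.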